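Amine side-chain variation on a shared core: working notes

This account rests on a few compounds, and the source may have more. Where it says the series, first, only, none or still open, it means among the compounds named here.

Measured so far:
compound 1 `CN(C)CCNc1nc(NCc2ccco2)c2ccccc2n1` — 21.7%
compound 2 `CCCCCNc1nc(NCc2ccco2)c2ccccc2n1` — "not determined" (no result reported)
compound 3 `CN(C)CCCNc1nc(NCc2ccco2)c2ccccc2n1` — "not determined" (no result reported)

Compound 3 stands at "not determined" (no result reported) in a functional assay on HT-29 cells (Homo sapiens) for cytotoxicity, read by MTT assay, with a stated time of 2 days, tested at 10 uM; on this read-out higher numbers stand for more inhibition at the one concentration tested (going by the name of the read-out) and lower numbers for less inhibition; compound 2 likewise stands at "not determined" (no result reported) there. Among the measured compounds shown here, the only value in this assay comes from compound 1, which gives 21.7%. The next compound, compound 4 `CCN(CC)CCNc1nc(NCc2ccco2)c2ccccc2n1`, differs from compound 3 by diethylamino in place of (dimethylamino)methyl on a saturated chain carbon, two bonds along the chain from a nitrogen on an aromatic ring. For the measured compounds named here, no measured pair shows a step, so the size of the change in this assay cannot be read from the data; the expectation is a step of no more than the usual scatter, in no particular direction, with compound 1 as the only anchor for the level. On that basis compound 4 is expected to give 22% in this assay, within 5% to 42%.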

Compound 4, a percentage reported as inhibition, at one concentration (the size of the read-out at that concentration, not a potency): 75.1%
Compound 4: middle estimate off by 53.1 percentage points, on the low side; measured number outside the range, above it.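

In this assay this position on the side chain is not a silent one: diethylamino in place of dimethylamino, on a saturated chain carbon, two bonds along the chain from a nitrogen on an aromatic ring, gives a number 53.4 percentage points higher from compound 1 to compound 4 (beyond the scatter) on the shared core. The steps to compound 2 and compound 3 cannot be read. Nothing available here accounts for the size of this step.

Still open, as far as these compounds go, is whether dipropylamino, pyrrolidine or morpholine in this place would hold the level of compound 4. Also open, from the compounds shown here alone, is how 3-(diethylamino)propyl, the longer chain, would compare.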